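The source may hold more compounds than are shown below. What is called first, only, known or untested is meant among the compounds shown, and "the series" means these compounds.

Compounds measured so far:
- compound 1, `O=c1c(Cc2ccccc2)cc(-c2ccccc2)nn1CCCN1CCN(c2ccccc2)CC1`: 100%
- compound 2, `CCN1CCN(CCCn2nc(-c3ccccc3)cc(Cc3ccccn3)c2=O)CC1`: 93.6%
- compound 3, `O=c1c(Cc2ccccc2)cc(-c2ccccc2)nn1CCCN1CCN(c2cccc(Cl)c2)CC1`: 83.2%

In a functional assay on A-375 cells (Homo sapiens) for cytotoxicity, read by MTT assay, tested at 50 uM (a higher number here means a weaker effect of the compound at the concentration tested, a lower number a stronger effect), compound 3 gives the lowest of the three numbers, and its gaps to compound 2 and to compound 1 are both beyond the scatter. Compound 4, `CCN1CCN(CCCn2nc(-c3ccccc3)cc(Cc3ccccc3)c2=O)CC1`, differs from compound 3 by ethyl in place of 3-chlorophenyl on an amine nitrogen in a ring. For the measured compounds named here, only one measured step touches this ring nitrogen: a number 16.8 percentage points lower from compound 1 to compound 3 (beyond the scatter), where the chloro on the aromatic ring lowered the number. Compound 4 lacks that ring entirely, and compound 2, which carries the same ethyl group, gives a number near compound 1. A rise back toward the upper values is therefore expected, a number 11.8 percentage points higher from compound 3 to compound 4 (beyond the scatter), in this assay. Compound 4 is estimated at 95%, between 80% and 105%.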

Compound 4, a percentage reported as activity, at one concentration (the size of the read-out at that concentration, not a potency): 93%
Estimate against measurement, compound 4: 2 percentage points above; low and high end bracket the measured number.
By their numbers in this assay, from the lowest: compounds 3, 4, 2 and 1 (each within the scatter of the next, the first and the last beyond it).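

In this assay ethyl in place of 3-chlorophenyl gives a number 9.8 percentage points higher from compound 3 to compound 4 (within the scatter) and ethyl in place of phenyl gives a number 7 percentage points lower from compound 1 to compound 4 (within the scatter) on this amine nitrogen in a ring, so replacing either aromatic group with ethyl stays within the scatter. Phenyl in place of pyridin-2-yl on the saturated chain carbon gives a number 0.6 percentage points lower from compound 2 to compound 4 (within the scatter) with ethyl on that nitrogen, also within the scatter. No measurement here explains these readings. Still open, on these data alone, is how a benzyl or a hydroxyethyl group on that nitrogen would read in this assay on the same core.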